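Same atoms, joined differently: from compound 1 to compound 3

A few compounds are considered here, and "the series" means these few. Any claim that something is new, unique, unknown or untested is made for them only; others in the source may bear on it.

Measured so far:
- Compound 1 `COC1=C(C)C(=O)O/C1=C\C(C)CCC/C(C)=C/CC/C(C)=C/CCC1=CC(O)OC1=O` gives 2 mm 
- Compound 2 `CC1=C(O)/C(=C/C(C)CCC/C(C)=C/CC/C(C)=C/CCc2ccoc2)OC1=O` gives 1 mm 

These numbers come from an ADME assay on BSC cells (Rattus norvegicus) for cytotoxicity (on this read-out higher numbers stand for wider zones without growth and lower numbers for narrower zones), and this small set offers only a first look. Compound 1 stands at 2 mm and compound 2 at 1 mm so the two lie within the usual scatter of each other and neither stands apart.

Compound 3 `COC1=C(C)C(=O)O/C1=C\C(C)CCC/C(C)=C/CC/C(C)=C/CCC1=CC(=O)OC1O` has not yet been measured. Its difference from compound 1 is simple to state (a group of 7 heavy atoms (4 carbon, 3 oxygen; one five-membered non-aromatic ring with 1 hetero atom) in place of a group of 7 heavy atoms (4 carbon, 3 oxygen; one five-membered non-aromatic ring with 1 hetero atom), on a saturated chain carbon, two bonds along the chain from a double-bonded chain carbon) and the two have the same atoms, joined differently. Going by the values given here, no two measured compounds differ in only one place, so the data offer no direct guide to this change. With so little to go on, no step beyond the scatter is expected, in either direction. The expected size of the change is no change at the digits printed from compound 1 to compound 3 (within the scatter) in this assay and this is only an estimate. Compound 3 is expected at 2 mm (estimated range 0 mm to 5 mm).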

Compound 3, diameter of the zone without growth: 1 mm
Compound 3: the middle estimate sits 1.0 mm above what was measured; measured number inside the range.
By their numbers in this assay, from the lowest: compounds 2, 3 and 1 (each within the scatter of the next).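

In this assay, the group of 7 heavy atoms on a saturated chain carbon, two bonds along the chain from a double-bonded chain carbon, was exchanged for one with the same atoms joined differently, and this gives a number 1.0 mm lower from compound 1 to compound 3 (within the scatter). Going by these compounds alone, this is the first pair in the set that differs in only one place, so it offers the first direct look at this position: this particular rearrangement of the five-membered ring group produces no difference that can be told apart from ordinary repeat variation. Nothing available explains the result or shows what either form of the group does at this position.

From the compounds shown here alone, a single pair within the scatter says nothing about how much this position can tolerate, so it remains unknown whether a truly different group there, such as a carboxylic acid, an amine or a longer chain, would produce a step beyond the scatter. Going by these compounds, it is also open whether the same rearrangement would give a similarly small step on a core with other changes elsewhere.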